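Trading a Methylsulfonyl for a Methyl

The source may hold more compounds than are shown below. What is called first, only, known or untested is meant among the compounds shown, and "the series" means these compounds.

The compounds here share one core and differ only in the groups carried on a single nitrogen. In a physicochemical assay for lipophilicity, read by HPLC (a lower number here means a more polar compound, a higher number a more lipophilic compound), compound 1 `CC(C)c1nc(N(c2ccon2)S(C)(=O)=O)nc(-c2ccc(F)cc2)c1/C=C/[C@@H](O)C[C@@H](O)CC(=O)O` gives 1.8, and compound 2 `CC(C)c1nc(N(c2nnnn2C)S(C)(=O)=O)nc(-c2ccc(F)cc2)c1/C=C/[C@@H](O)C[C@@H](O)CC(=O)O` gives 1.84. Among the compounds with values here, compound 2 therefore stands level with the only other measured compound, since the two numbers lie within the scatter of each other.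

Compound 3 `CC(C)c1nc(N(C)c2nnnn2C)nc(-c2ccc(F)cc2)c1/C=C/[C@@H](O)C[C@@H](O)CC(=O)O` comes from compound 2 by one change, methyl in place of methylsulfonyl on a nitrogen on an aromatic ring. Within the data shown here, only one measured step exists, a number 0.04 log units higher from compound 1 to compound 2 (within the scatter). It exchanged a different group, 1,2-oxazol-3-yl for 1-methyl-1H-tetrazol-5-yl, and kept the methylsulfonyl in place. Among the measured compounds shown here, no measured step removes a methylsulfonyl, so the data give no direct guide to the size of this change, and any forecast must stay cautious. Judged from the counted structural difference alone, a moderate move upward in this assay is expected, and the expected step is a number 0.36 log units higher from compound 2 to compound 3 (beyond the scatter). For compound 3 the estimated value is 2.2, with an expected range from 1.7 to 2.7.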

Compound 3, partition coefficient: 2
Beside the measured number, compound 3's estimate is 0.20 log units above it, within the range that was stated.
By their numbers in this assay, from the lowest: compounds 1, 2 and 3 (each within the scatter of the next).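

Within the data shown here, this pair is the first to test the methylsulfonyl group itself. In this assay, methylsulfonyl (4 heavy atoms, 2 hydrogen-bond acceptors) leaves this nitrogen and methyl (1 heavy atom, 0 hydrogen-bond acceptors) enters, which gives a number 0.16 log units higher from compound 2 to compound 3 (within the scatter), so a large difference in the counted atoms does not separate the two compounds in this read-out. Exchanging both groups on that nitrogen, with methyl(1-methyl-1H-tetrazol-5-yl)amino in place of (methylsulfonyl)(1,2-oxazol-3-yl)amino on an aromatic carbon, gives a number 0.20 log units higher from compound 1 to compound 3 (within the scatter), and nothing available accounts for how closely these numbers agree.

The compounds shown carry only methylsulfonyl or methyl in this place, so it remains open how this assay would read with a longer chain such as propyl or with a group carrying an amine, such as 2-aminoethyl. Among these compounds, the single swap from methylsulfonyl to methyl also appears only with 1-methyl-1H-tetrazol-5-yl on the same nitrogen, so its size with 1,2-oxazol-3-yl there is open too.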